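This account rests on a few compounds, and the source may have more. Where it says the series, first, only, none or still open, it means among the compounds named here.

In a functional assay on SK-N-SH cells (Homo sapiens) for inhibition, read by MTT assay, with a stated time of 72 h, tested at 30 uM (a higher number here means more inhibition of growth at the concentration tested, a lower number less inhibition of growth), compound 1 `C=CCc1cc(O)c(O)c(CN2CCC(C)CC2)c1` gives 74.7%. Compound 2 `C=CCc1ccc(OCc2cn(-c3ccc(C#N)cc3)nn2)c(O)c1` gives 37.5%, well under compound 1 and beyond the usual scatter of repeat measurements. Compound 3 `C=CCc1ccc(OCc2cn(-c3cc(OC)c(OC)c(OC)c3)nn2)c(O)c1` gives 44.1%, within the scatter of compound 2.

Compound 4 `C=CCc1ccc(OCc2cn(-c3ccccc3Cl)nn2)c(O)c1` is compound 2 with a single change: 2-chlorophenyl in place of 4-cyanophenyl on an aromatic nitrogen, which puts 2-chlorophenyl in place of 4-cyanophenyl on an aromatic nitrogen. Among the compounds with values here, no measured pair shows a single change directly. Compared with compound 2, compound 3 carries a different group on that same nitrogen and gives 44.1%, so no shift beyond the scatter is expected here. The estimated change, a number 4.5 percentage points higher from compound 2 to compound 4 (within the scatter), is small and upward. For compound 4 the expected value is 42%, with an estimated range of 25% to 60%.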

Compound 4, percent growth inhibition at one concentration: 10.2%
Beside the measured number, compound 4's estimate is 31.8 percentage points above it; measured number outside the range, below it.
By their numbers in this assay, from the lowest: compound 4; then compounds 2 and 3 (each within the scatter of the next); then compound 1.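

The group on this aromatic nitrogen matters more than compounds 2 and 3 suggested, since those two stand within the scatter of each other: in this assay, 2-chlorophenyl in place of 4-cyanophenyl gives a number 27.3 percentage points lower from compound 2 to compound 4 (beyond the scatter). Both the substituent and its place on the phenyl ring change in this one step. No measurement shown here explains the drop.

From the compounds shown here alone, whether the chlorine or its place drives the step remains open. A 4-chlorophenyl or 2-cyanophenyl group on the same nitrogen would separate the two.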